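Furan in place of tolyl on the saturated ring carbon

The source may hold more compounds than are shown below. What is called first, only, known or untested is meant among the compounds shown, and "the series" means these compounds.

Of the compounds shown here, three sharing one core have been tested in a functional assay on Ehrlich cells (Mus musculus) for cytotoxicity, tested at 50 ug/mL; on this read-out higher numbers stand for a stronger effect at the one concentration tested and lower numbers for a weaker effect. Compound 1 `COc1cc(N2C(N)=C(C#N)C(c3ccc([N+](=O)[O-])cc3)C3=C2CC(C)(C)CC3=O)cc(OC)c1OC` gives 70%, compound 2 `COc1cc(N2C(N)=C(C#N)C(c3c(O)ccc4ccccc34)C3=C2CC(C)(C)CC3=O)cc(OC)c1OC` gives 15%, and compound 3 `COc1cc(N2C(N)=C(C#N)C(c3ccc(C)cc3)C3=C2CC(C)(C)CC3=O)cc(OC)c1OC` gives 60%. Compound 3 thus stands second highest of the three numbers: its nearest neighbour is compound 1, with a value within the scatter, and its furthest is compound 2, with a value far lower.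

Compound 4 `COc1cc(N2C(N)=C(C#N)C(c3ccc(C)o3)C3=C2CC(C)(C)CC3=O)cc(OC)c1OC` has not yet been measured in this assay. It differs from compound 3 as follows: 5-methylfuran-2-yl in place of 4-methylphenyl on a saturated ring carbon. Two measured steps change the group on that same saturated ring carbon: a number 55 percentage points lower from compound 1 to compound 2 (beyond the scatter) and a number 45 percentage points higher from compound 2 to compound 3 (beyond the scatter), both large. The third step, a number 10 percentage points lower from compound 1 to compound 3 (within the scatter), changed only a substituent on the aromatic ring and stayed within the scatter. Among the compounds with values here, the exchange of a six-membered carbon ring for a five-membered ring with one oxygen has no direct precedent here, so a moderate change in either direction remains possible. Compound 4 is expected to show 50%, between 20% and 75%, meaning an estimated step of a number 10 percentage points lower from compound 3 to compound 4 (within the scatter).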

Compound 4, a percentage reported as activity, at one concentration (the size of the read-out at that concentration, not a potency): 41%
Beside the measured number, compound 4's estimate is 9 percentage points above it; the measured number falls inside the stated range.
By their numbers in this assay, from the lowest: compound 2; then compound 4; then compounds 3 and 1 (each within the scatter of the next).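

At the saturated ring carbon, a five-membered aromatic ring with one oxygen does not match the two para-substituted phenyl groups in this assay: 5-methylfuran-2-yl gives a number 19 percentage points lower from compound 3 to compound 4 (beyond the scatter) and a number 29 percentage points lower from compound 1 to compound 4 (beyond the scatter). It still keeps more of the effect than the 2-hydroxynaphthalen-1-yl group, with a number 26 percentage points higher from compound 2 to compound 4 (beyond the scatter), so this position gives an intermediate level as well as the high and low levels seen earlier. No measurement available here explains this ordering.

The compounds shown leave open whether the drop tracks the ring oxygen, the smaller ring or the position of the methyl group. A 5-methylthiophen-2-yl or an unsubstituted furan-2-yl group on this carbon would begin to separate these possibilities.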